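The source may report more compounds than this note shows. Statements on the series, on what has been measured and on what is new or still open speak of the compounds shown alone.

Three compounds built on one shared core have been examined in a functional assay on SK-MEL-5 cells (Homo sapiens) for cytotoxicity, read by sulforhodamine B assay, with a stated time of 48 h, tested at 0.1 uM; a lower number here means a stronger effect, a higher number a weaker effect of the compound at the concentration tested. Compound 1 `COc1cc(-c2cc(/C=C/C(=O)c3ccc(Cl)c(Cl)c3)[nH]n2)cc(OC)c1OC` gives 97%. Compound 2 `COc1ccc(C(=O)/C=C/c2cc(-c3cc(OC)c(OC)c(OC)c3)n[nH]2)cc1OC` gives 96% in this assay. Compound 3 `COc1ccc(C(=O)/C=C/c2cc(-c3cc(OC)c(OC)c(OC)c3)n[nH]2)cc1` gives 99% in this assay. Compound 3 carries the highest of the three numbers, yet the steps of a number 2 percentage points higher from compound 1 to compound 3 (within the scatter) and a number 3 percentage points higher from compound 2 to compound 3 (within the scatter) show that it sits within the scatter of both others, so no order among the three can be claimed.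

Compound 4 `COc1cc(-c2cc(/C=C/C(=O)c3ccc(F)c(F)c3)[nH]n2)cc(OC)c1OC` has not yet been measured in this assay. It differs from compound 3 in one place: 3,4-difluorophenyl in place of 4-methoxyphenyl on a carbonyl carbon. The step that bears most directly on this change is a number 2 percentage points higher from compound 1 to compound 3 (within the scatter), where a dihalogenated ring on the carbonyl carbon gave way to the 4-methoxyphenyl; the step of a number 1 percentage points lower from compound 1 to compound 2 (within the scatter) also changed the ring on that carbonyl carbon without moving the number beyond the scatter. Compound 4 is therefore expected to show a number 2 percentage points lower from compound 3 to compound 4 (within the scatter), nothing beyond the scatter. Compound 4 is estimated at 97% in this assay, in a range from 89% to 104%.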

Compound 4, a percentage reported as activity, at one concentration (the size of the read-out at that concentration, not a potency): 96%
Estimate against measurement, compound 4: 1 percentage points above, and the stated range covers the measured number.
By their numbers in this assay, from the lowest: compounds 2, 4, 1 and 3 (each within the scatter of the next).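

In this assay the change to 3,4-difluorophenyl on a carbonyl carbon gives a number 3 percentage points lower from compound 3 to compound 4 (within the scatter) and no change at the digits printed from compound 2 to compound 4 (within the scatter) and a number 1 percentage points lower from compound 1 to compound 4 (within the scatter) when set against the three other rings. A fourth ring at this position, the second with two halogens, therefore stays with the others, and none of the four rings yet separates from the rest. Nothing available here explains why these numbers stay together.

On these data alone, whether an amine, a carboxylic acid or a longer chain on the carbonyl carbon in place of the ring would move the number remains open. Also open is whether these four compounds, which cannot be told apart at the single concentration shown, would separate at a higher concentration.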